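Hydroxy in place of hydrogen on the acetamido of compound 2

The compounds below may be only part of what the source reports. "The series", "measured", "known", "first", "only" and "open" are said of these compounds alone.

Measured compounds:
- compound 1, `C#CCNC1CCc2c(NCc3ccc(C)cc3)cccc21`, 43100 nM
- compound 2, `C#CCNC1CCc2c(OCCc3cc(NC(C)=O)ccc3Cl)cccc21`, 85200 nM

In an ADME assay on cells for inhibition of Amine oxidase [flavin-containing] A (Homo sapiens), read by fluorescence and Amplex Red, with stated times of 30 min and 15 min (a higher number here means a weaker inhibitor, a lower number a stronger inhibitor), compound 2 gives 85200 nM, the higher of the two numbers recorded, while compound 1 gives 43100 nM. For the measured compounds named here, the gap between compound 1 and compound 2 lies within the scatter of the method, so the two cannot be told apart on these numbers, and no structural step between them has been worked out.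

Compound 3, `C#CCNC1CCc2c(OCCc3cc(NC(=O)CO)ccc3Cl)cccc21`, differs from compound 2 in one place: hydroxy in place of hydrogen on a saturated chain carbon bound to a carbonyl carbon. The rest of the molecule, including the shared core and the chain that carries the chloro-substituted ring, is unchanged.

Going by the values given here, no step of this kind has been measured in this set, so the expectation rests on the closeness of compound 2 to compound 1 and on the smallness of the change itself. Compound 3 is expected to sit close to compound 2, with a step of a 1.1-fold lower number from compound 2 to compound 3 (0.03 log units; within the scatter) that is not expected to go beyond the scatter in either direction. Compound 3 is estimated at 80000 nM, in a range from 30000 nM to 200000 nM.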

Compound 3, half-maximal inhibitory concentration: 252000 nM
For compound 3 the middle estimate is 3.2-fold (0.50 log units) below the measured one, and the stated range ends below it.
By their numbers in this assay, from the lowest: compounds 1 and 2 (each within the scatter of the next); then compound 3.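

In this assay, hydroxy in place of hydrogen on a saturated chain carbon bound to a carbonyl carbon gives a 3.0-fold higher number from compound 2 to compound 3 (0.47 log units; beyond the scatter) and so makes compound 3 the weaker inhibitor of that pair by a modest margin. For the compounds shown here, this is the first change in the set that can be read at a single place: compound 1 and compound 2 offered no such step, whereas here methyl to hydroxymethyl within the acetamido, with the rest of the molecule unchanged, shows that this position does not accept every small change without a shift in the number. No measurement at hand accounts for the direction or the size of this shift.

The compounds shown leave open whether the shift belongs to the hydroxy itself or would also follow other groups on the same carbon, such as a methoxy, an amine or a fluorine. They also leave open whether a longer chain carrying the hydroxy at its end, or a carboxylic acid in place of the hydroxymethyl, would move the number further or bring it back toward that of compound 2.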